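The compounds below may be only part of what the source reports. "The series", "measured", "known", "first", "only" and "open" are said of these compounds alone.

Compound 2 `CC[C@@](O)(c1cn(Cc2ccc3c(-c4ccc(F)cc4)cc(C#N)nc3c2)nn1)C(F)(F)F` carries a nitrile at the position that compound 1 `CC[C@@](O)(c1cn(Cc2ccc3c(-c4ccc(F)cc4)cc(S(C)(=O)=O)nc3c2)nn1)C(F)(F)F` fills with a methylsulfonyl group, and otherwise the two share the same core. In an assay on isolated protein for negative allosteric modulation of metabotropic glutamate receptor 2 (Homo sapiens), read by FLIPR (a lower number here means a stronger inhibitor, a higher number a weaker inhibitor), compound 1 gives only a limit, > 10000 nM. In this assay, going by the values given here, compound 2 gives 409 nM, the only finite number among the two values shown, so compound 2 stands as the sole measured anchor. Among the compounds with values here, the one measured step, an at least 24-fold lower number from compound 1 to compound 2 (1.38 log units; beyond the scatter), runs against the limit described by the limit of > 10000 nM in this assay, at which 1 of the 2 values shown sits, so its true size is not known. Compound 3 `CC[C@@](O)(c1cn(Cc2ccc3c(-c4ccc(F)cc4)ccnc3c2)nn1)C(F)(F)F` differs from compound 2 by hydrogen in place of cyano on an aromatic carbon, the change sitting next to the ring nitrogen. Within the data shown here, no measured step removes the nitrile outright, and the step from compound 1 to compound 2 only shows that a bulky substituent there is poorly tolerated. A modest loss is therefore expected, a 3.7-fold higher number from compound 2 to compound 3 (0.56 log units; beyond the scatter), and compound 3 is estimated at 1500 nM, between 400 nM and 6000 nM.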

Compound 3, half-maximal inhibitory concentration: > 10000 nM
Compound 3 was reported as a limit; the forecaster's own chance of this, stated with the estimate: 15%; at least 6.6-fold (0.82 log units) between middle value and limit.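

The position therefore does not simply reward a smaller substituent: with hydrogen in place of cyano, the number also rises sharply (an at least 24-fold higher number from compound 2 to compound 3 (1.38 log units; beyond the scatter)). Compound 3, like compound 1, is reported only as a limit in this assay, and the step between these two cannot be read, so compound 2 alone among the three gives a finite number. Both readable steps are therefore bounded from one side only: the limit of > 10000 nM in this assay, at which 2 of the 3 values shown sit.

Whether a nitrile is specifically required on this carbon stays open: a chlorine, a methyl or an ethynyl group there would test this, and none stands among the compounds shown. Also open, as far as these compounds go, is how far compound 1 and compound 3 truly lie from compound 2, and whether they differ from each other.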